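This account rests on a few compounds, and the source may have more. Where it says the series, first, only, none or still open, it means among the compounds named here.

Series notes, aryl sulfonyl variation on the shared core.

Compound 3 `N#Cc1cccc(S(=O)(=O)c2cnc3c(F)cccc3c2-c2cccc(F)c2)c1` gives 0.34 mL/min in an ADME assay on microsomes from liver (Homo sapiens) for metabolic stability, tested at 2.5 uM (a lower number here means slower removal, a higher number faster removal of the compound), the lowest of the three numbers in hand. Compound 2 `O=S(=O)(c1ccc(F)c(Cl)c1)c1cnc2c(F)cccc2c1-c1cccc(F)c1` gives 1.23 mL/min and compound 1 `COc1ccc(S(=O)(=O)c2cnc3c(F)cccc3c2-c2cccc(F)c2)cc1` gives 3.03 mL/min in this assay, so the spread across the aryl group on the sulfonyl sulfur covers an 8.9-fold lower number from compound 1 to compound 3 (0.95 log units; beyond the scatter) and a 3.6-fold lower number from compound 2 to compound 3 (0.56 log units; beyond the scatter), with a 2.5-fold lower number from compound 1 to compound 2 (0.39 log units; beyond the scatter) between the two halogenated and methoxy variants.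

Compound 4 `O=S(=O)(c1cccc(F)c1)c1cnc2c(F)cccc2c1-c1cccc(F)c1` is the next member; against compound 3 the change is fluoro in place of cyano on an aromatic carbon. The 3-cyanophenyl of compound 3 sits at the low end of this assay, and the two steps that reach it, an 8.9-fold lower number from compound 1 to compound 3 (0.95 log units; beyond the scatter) and a 3.6-fold lower number from compound 2 to compound 3 (0.56 log units; beyond the scatter), both run downward toward it. Compound 4, carrying a 3-fluorophenyl, is nearer in kind to the 3-chloro-4-fluorophenyl of compound 2 than to the cyano-bearing ring, so the expected movement is back upward in this assay, of a size estimated at a 2.9-fold higher number from compound 3 to compound 4 (0.47 log units; beyond the scatter), beyond the scatter but short of the full return to compound 1. Compound 4 is therefore estimated at 1 mL/min in this assay, with a range of 0.4 mL/min to 2.5 mL/min, pending measurement.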

Compound 4, intrinsic clearance in a liver preparation (reported as CLH), per the amount of preparation that the assay uses: 1.14 mL/min
The estimate for compound 4 lay 1.1-fold (0.06 log units) below the measured number, within the range that was stated.
By their numbers in this assay, from the lowest: compound 3; then compounds 4 and 2 (each within the scatter of the next); then compound 1.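

Fluoro in place of cyano on this aromatic carbon, meta to a large group, gives a 3.4-fold higher number from compound 3 to compound 4 (0.53 log units; beyond the scatter) in this assay, so the low number of compound 3 belongs to the cyano group specifically and is not shared by every single substituent at this place on the ring. The 3-fluorophenyl and 3-chloro-4-fluorophenyl rings cannot be told apart, with a 1.1-fold lower number from compound 2 to compound 4 (0.03 log units; within the scatter), so adding the chloro and moving from one fluoro to the chloro-fluoro pattern leaves no readable mark here, while a 2.7-fold lower number from compound 1 to compound 4 (0.42 log units; beyond the scatter) keeps the 3-fluorophenyl clearly apart from the 4-methoxyphenyl, and the four compounds fall into three levels, with the two halogen-bearing rings together in the middle. No measurement in hand bears on the reason for these differences.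

Still open, as far as these compounds go, is whether the low number is special to the cyano group or would also appear with a primary amide, an amine or a carboxylic acid on the same aromatic carbon. The compounds shown also leave open whether a cyano group elsewhere on the ring would behave as it does in compound 3.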